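Changing the amide nitrogen substituents on the shared core

The compounds below may be only part of what the source reports. "The series", "measured", "known", "first", "only" and "open" are said of these compounds alone.

Compound 1 `CCOC(=O)c1sc2nc(SC)nc(-c3cccc(OC)c3)c2c1N` gives 1.5%
Compound 2 `COc1cccc(-c2nc(SC)nc3sc(C(=O)NCCO)c(N)c23)c1` gives 2.9%
Compound 3 `CCNC(=O)c1sc2nc(SC)nc(-c3cccc(OC)c3)c2c1N` gives 2.3%

All three were tested in a functional assay on HEK293 cells for agonist activity at Thyrotropin receptor (Homo sapiens), read by cAMP accumulation; on this read-out higher numbers stand for larger maximal responses and lower numbers for smaller maximal responses. The values sit close together: a number 1.4 percentage points higher from compound 1 to compound 2 (within the scatter) and a number 0.8 percentage points higher from compound 1 to compound 3 (within the scatter), both within the scatter. On the numbers alone compound 3 lies between the other two, but no ordering beyond the scatter can be read from this.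

Compound 4 `COc1cccc(-c2nc(SC)nc3sc(C(=O)N(C)C)c(N)c23)c1` differs from compound 3 in one place: dimethylamino in place of ethylamino on a carbonyl carbon. Among the compounds with values here, the steps that bear on a change at this carbonyl carbon are a number 0.8 percentage points higher from compound 1 to compound 3 (within the scatter) and a number 0.6 percentage points lower from compound 2 to compound 3 (within the scatter); neither moved the response beyond the scatter. The expected step of a number 0.2 percentage points higher from compound 3 to compound 4 (within the scatter) is therefore none beyond the scatter. Compound 4 is estimated at 2.5%, with a range from 0% to 10%.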

Compound 4, largest response reached (reported as efficacy), in percent of the reference or control that the assay uses: 4%
The estimate for compound 4 lay 1.5 percentage points below the measured number, within the range that was stated.
By their numbers in this assay, from the lowest: compounds 1, 3, 2 and 4 (each within the scatter of the next).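

Compound 4 carries no amide hydrogen, unlike compound 3, yet in this assay this change does not shift the response beyond the scatter (a number 1.7 percentage points higher from compound 3 to compound 4 (within the scatter)). The other two steps read the same way (a number 1.1 percentage points higher from compound 2 to compound 4 (within the scatter); a number 2.5 percentage points higher from compound 1 to compound 4 (within the scatter)), so ethoxy, ethylamino, (2-hydroxyethyl)amino and dimethylamino on this carbonyl carbon cannot be told apart here. No measurement at hand offers an explanation for these numbers.

From the compounds shown here alone, whether a carboxylic acid, or a longer chain ending in an amine, on this carbonyl carbon would move the response beyond the scatter remains open.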